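The source may hold more compounds than are shown below. What is called first, only, known or untested is meant among the compounds shown, and "the series" means these compounds.

For the measured compounds named here, in a functional assay on MCF7 cells (Homo sapiens) for antiproliferative activity, read by sulforhodamine B assay, with a stated time of 48 h (on this read-out higher numbers stand for weaker inhibition and lower numbers for stronger inhibition), compound 1 (`Cc1ccc(NS(=O)(=O)c2ccc(N3CCNC3=O)cc2)cc1C`) gives 230 nM and compound 2 (`O=C1NCCN1c1ccc(S(=O)(=O)Nc2cccc(Br)c2)cc1`) gives 100 nM as the lower of the two numbers so far. Compound 3 (`O=C1NCCN1c1ccc(S(=O)(=O)Nc2cccc(Cl)c2)cc1`) differs from compound 2 in one place (chloro in place of bromo on an aromatic carbon) with chloro in place of bromo on an aromatic carbon. Going by the values given here, only one measured step bears on this, and only loosely: a 2.3-fold lower number from compound 1 to compound 2 (0.36 log units; beyond the scatter) for 3-bromophenyl in place of 3,4-dimethylphenyl on a sulfonamide nitrogen. Among the compounds with values here, no measured step yet swaps one halogen for another, so no change beyond the scatter is expected in this assay. The expected step is a 1.3-fold higher number from compound 2 to compound 3 (0.11 log units; within the scatter) in either direction. Compound 3 is estimated at 130 nM with a likely range (60 nM to 280 nM).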

Compound 3, half-maximal inhibitory concentration: 79 nM
Compound 3: the middle estimate sits 1.6-fold (0.22 log units) above what was measured; the measured number falls inside the stated range.
By their numbers in this assay, from the lowest: compounds 3 and 2 (each within the scatter of the next); then compound 1.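

Swapping bromo for chloro on the aromatic carbon gives a 1.3-fold lower number from compound 2 to compound 3 (0.10 log units; within the scatter) in this assay, so these two halogens cannot be told apart at this position. Replacing 3,4-dimethylphenyl with 3-chlorophenyl gives a 2.9-fold lower number from compound 1 to compound 3 (0.46 log units; beyond the scatter), which shows that a second halogen, not bromo alone, goes with a number beyond the scatter from that of compound 1. No measurement shown here explains either step. Still open, from the compounds shown here alone, is whether fluoro, methoxy or an amine at this position would give a similar number in this assay.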